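Swapping a carbamate chain for a sulfonamide on a shared core

This account rests on a few compounds, and the source may have more. Where it says the series, first, only, none or still open, it means among the compounds named here.

Compound 1 `CC(C)(C)OC(=O)NCCCNC(=O)CN1CN(c2ccccc2)C2(CCN(C(=O)c3ccc(C(C)(C)C)cc3)CC2)C1=O` carries a 2-((tert-butoxycarbonyl)amino)ethyl group on a saturated chain carbon bound to an amide-type nitrogen. In an assay on HEK293 cells for displacement of a labelled ligand from NPC1-like intracellular cholesterol transporter 1 (Homo sapiens) (a lower number here means a stronger inhibitor, a higher number a weaker inhibitor), compound 1 gives 4500 nM. Compound 2 `CC(C)(C)c1ccc(C(=O)N2CCC3(CC2)C(=O)N(CC(=O)NCNS(C)(=O)=O)CN3c2ccccc2)cc1` differs from it by methanesulfonamido in place of 2-((tert-butoxycarbonyl)amino)ethyl on a saturated chain carbon bound to an amide-type nitrogen and in this assay compound 2 gives 3200 nM. The step of a 1.4-fold lower number from compound 1 to compound 2 (0.15 log units; within the scatter) means the two numbers cannot be told apart.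

Compound 3 `CC(C)(C)OC(=O)NCCCCNC(=O)CN1CN(c2ccccc2)C2(CCN(C(=O)c3ccc(C4CCCCC4)cc3)CC2)C1=O` rests on a different core; the difference between the core of compound 3 and that of compound 1 is not broken down here. In this assay compound 3 gives 4600 nM.

Compound 4 `CS(=O)(=O)NCCNC(=O)CN1CN(c2ccccc2)C2(CCN(C(=O)c3ccc(C4CCCCC4)cc3)CC2)C1=O` has not yet been measured. Relative to compound 3 the change is methanesulfonamido in place of 2-((tert-butoxycarbonyl)amino)ethyl on a saturated chain carbon, two bonds along the chain from an amide-type nitrogen. This is the same kind of change as that from compound 1 to compound 2, but the place is not identical: there the group sat on a saturated chain carbon bound to an amide-type nitrogen, here on a saturated chain carbon two bonds along the chain from an amide-type nitrogen. The earlier step of a 1.4-fold lower number from compound 1 to compound 2 (0.15 log units; within the scatter) stayed within the scatter. On that basis the expected step for compound 4 is a 1.4-fold lower number from compound 3 to compound 4 (0.14 log units; within the scatter). Compound 4 is therefore estimated at 3300 nM, most likely between 1500 nM and 7500 nM.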

Compound 4, half-maximal inhibitory concentration: 2100 nM
Beside the measured number, compound 4's estimate is 1.6-fold (0.20 log units) above it, and the stated range covers the measured number.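

In this assay, putting methanesulfonamido in place of 2-((tert-butoxycarbonyl)amino)ethyl gives a 2.2-fold lower number from compound 3 to compound 4 (0.34 log units; beyond the scatter), a modest gain in strength. Compared with the earlier step, the change behaves alike on the two cores as far as these numbers can tell: the same change on two cores in this assay, a 1.4-fold lower number (0.15 log units; within the scatter) from compound 1 to compound 2 and a 2.2-fold lower number (0.34 log units; beyond the scatter) from compound 3 to compound 4, 1.6-fold (0.19 log units) apart, within the scatter of two such steps. Going by these compounds alone, this shows only that the swap carried over without a detectable difference in this one pair of cores; with just two steps, one of them indistinguishable from no change, it does not show that the swap lowers the number on every core, and it gives no reason for the effect.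

The compounds shown leave open whether another end group at this place, such as a free amine or a carboxylic acid, would shift the number further. They also leave open whether a longer chain carrying the methanesulfonamido group would do better or worse than the chains seen here.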